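Sulfonyl Substituent Change on a Sulfonamide Nitrogen in a Ring

This account rests on a few compounds, and the source may have more. Where it says the series, first, only, none or still open, it means among the compounds named here.

For the measured compounds named here, compound 2 `CN(C)c1ccc(C2CC(c3ccc(-n4cncn4)cc3)=NN2S(C)(=O)=O)cc1` is one of two compounds measured in a functional assay on MDA-MB-231 cells (Homo sapiens) for inhibition, read by sulforhodamine B assay, tested at 10 uM (on this read-out lower numbers stand for less inhibition and higher numbers for more inhibition at the one concentration tested (going by the name of the read-out)), where compound 2 gives 7.8%. Compound 1 `CN(C)c1ccc(C2CC(c3ccc(-n4cncn4)cc3)=NN2C(=O)CCCl)cc1` gives 3.7% in this assay. Going by the values given here, the only measured step, a number 4.1 percentage points higher from compound 1 to compound 2 (within the scatter), concerns the group on the ring nitrogen, not the sulfonyl sulfur. Compound 3 `Cc1ccc(S(=O)(=O)N2N=C(c3ccc(-n4cncn4)cc3)CC2c2ccc(N(C)C)cc2)cc1` differs from compound 2 by 4-methylphenyl in place of methyl on a sulfonyl sulfur. Among the compounds with values here, no measured step touches this position, so in this assay a step of a number 4.2 percentage points higher from compound 2 to compound 3 (within the scatter) is expected, not beyond the scatter. Compound 3 is therefore estimated to give 12% in this assay, with a range from 0% to 35%.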

Compound 3, a percentage reported as inhibition, at one concentration (the size of the read-out at that concentration, not a potency): 20.7%
Beside the measured number, compound 3's estimate is 8.7 percentage points below it; measured number inside the range.
By their numbers in this assay, from the lowest: compounds 1 and 2 (each within the scatter of the next); then compound 3.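

On the sulfonyl sulfur, this assay does respond to the substituent: 4-methylphenyl in place of methyl gives a step beyond the scatter (a number 12.9 percentage points higher from compound 2 to compound 3 (beyond the scatter)), which the earlier pair did not show. The group on the ring nitrogen can also shift the number beyond the scatter (a number 17 percentage points higher from compound 1 to compound 3 (beyond the scatter)), but only with (4-methylphenyl)sulfonyl, not with methylsulfonyl. No evidence is available to explain this step. As far as these compounds go, it remains open whether the ring or its methyl carries the step, and how a plain phenyl, a 4-aminophenyl or a longer alkyl chain on the sulfur would read.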